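The compounds below may be only part of what the source reports. "The series", "measured", "known", "first", "only" and "open" are said of these compounds alone.

Compound 1, `O=C1C[C@H](OCc2cn(-c3ccc(Cl)cc3)nn2)[C@H]2CO[C@@H]1O2`: in a functional assay on NCI-H1299 cells (Homo sapiens) for cytotoxicity, read by MTT assay, with a stated time of 48 h (on this read-out higher numbers stand for weaker inhibition and lower numbers for stronger inhibition), compound 1 gives 10600 nM.
Compound 2, `C=C(C)Cn1cc(CO[C@H]2CC(=O)[C@@H]3OC[C@H]2O3)nn1`: in this assay compound 2 gives 14300 nM.
Compound 3, `O=C1C[C@H](OCc2cc(-c3ccccc3)no2)[C@H]2CO[C@@H]1O2`: in this assay compound 3 gives 9800 nM.

The three compounds share a bicyclic ketone core carrying an ether-linked heteroaryl methyl group, and their numbers sit close together. Compound 3 lies near compound 1 and compound 2, and the gaps to both fall within the scatter of this assay, so no ordering among them can be claimed. Going by the values given here, the only step between two measured compounds that differ in a single place is a 1.3-fold higher number from compound 1 to compound 2 (0.13 log units; within the scatter), a swap of the group on the ring nitrogen of compound 1, which also stays within the scatter.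

Compound 4, `O=C1C[C@H](OCc2cc(-c3ccc([N+](=O)[O-])cc3)no2)[C@H]2CO[C@@H]1O2`, differs from compound 3 by nitro in place of hydrogen on an aromatic carbon. Among the compounds with values here, no measured step touches a substituent on this carbon ring; compound 1 and compound 3 carry different rings and differ elsewhere as well, so their two values show only that a chlorinated phenyl and a bare phenyl land close together. On that basis the step from compound 3 to compound 4 is expected to remain within the scatter, a 1.0-fold lower number from compound 3 to compound 4 (0.01 log units; within the scatter). Compound 4 is therefore estimated at 9500 nM, with a range from 4000 nM to 22000 nM.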

Compound 4, half-maximal inhibitory concentration: 11200 nM
The estimate for compound 4 lay 1.2-fold (0.07 log units) below the measured number; the range from low to high includes it.
By their numbers in this assay, from the lowest: compounds 3, 1, 4 and 2 (each within the scatter of the next).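

In this assay, the change on the carbon ring gives a 1.1-fold higher number from compound 3 to compound 4 (0.06 log units; within the scatter) for nitro in place of hydrogen on an aromatic carbon, para to a large group. Going by these compounds alone, this is the first measured step at a substituent on this ring, and it shows that this place takes nitro, a group with no ring and no net charge, without the number leaving the scatter, so compound 3 and compound 4 cannot be told apart. No measurement shown here bears on why this replacement leaves the read-out within the scatter, and no cause can be given.

On these data alone, whether an amine or a carboxylic acid in place of the same hydrogen would also stay within the scatter remains open, and one replacement cannot speak for this place as a whole. With each of the four compounds within the scatter of the next in this assay the series also leaves open which part of the structure, if any, can move the number beyond the scatter.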